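Ortho Substituent Swap on an EP2 Agonist Aryl Ether

The source may hold more compounds than are shown below. What is called first, only, known or untested is meant among the compounds shown, and "the series" means these compounds.

Compound 1, `O=C(O)c1csc([C@H]2CC[C@@H]3[C@@H](COc4cccc(Cl)c4)[C@H](O)C[C@@H]3O2)n1`: > 10000 nM
Compound 2, `O=C(O)c1csc([C@H]2CC[C@@H]3[C@@H](COc4ccccc4C(F)(F)F)[C@H](O)C[C@@H]3O2)n1`: 11 nM

In an assay on HEK293 cells for agonist activity at prostaglandin E2 receptor EP2 subtype (Homo sapiens), read by a beta-galactosidase reporter and beta-arrestin recruitment, with a stated time of 90 min (on this read-out lower numbers stand for an effect already at smaller amounts and higher numbers for an effect only at larger amounts of compound), compound 1 gives only a limit, > 10000 nM. For the measured compounds named here, compound 2 gives 11 nM, the single number obtained in this assay. Going by the values given here, the one measured step is an at least 900-fold lower number from compound 1 to compound 2 (2.95 log units; beyond the scatter); it changes both the group and its place on the ring, so it bears only loosely on the present change. Compound 3, `O=C(O)c1csc([C@H]2CC[C@@H]3[C@@H](COc4ccccc4Cl)[C@H](O)C[C@@H]3O2)n1`, differs from compound 2 by chloro in place of trifluoromethyl on an aromatic carbon. Since the place on the ring is kept and only the substituent changes, a smaller step is expected: a 4.5-fold higher number from compound 2 to compound 3 (0.66 log units; beyond the scatter). Compound 3 is estimated at 50 nM, with a likely range from 8 nM to 500 nM.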

Compound 3, half-maximal effective concentration: 203 nM
Estimate against measurement, compound 3: 4.1-fold (0.61 log units) below; measured number inside the range.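

Keeping the place on the ring, chloro in place of trifluoromethyl gives an 18-fold higher number from compound 2 to compound 3 (1.27 log units; beyond the scatter) in this assay, so the substituent itself counts at this position. Moving the chloro, 2-chlorophenyl in place of 3-chlorophenyl, gives an at least 49-fold lower number from compound 1 to compound 3 (1.69 log units; beyond the scatter), so its place on the ring counts as well, and the two parts of the earlier mixed step come apart. This second step rests on compound 1, which gives only a limit: the limit of > 10000 nM in this assay, at which 1 of the 3 values shown sits.

As far as these compounds go, how a methoxy or a fluoro group on that same aromatic carbon would read remains open. So does how trifluoromethyl would read at the place the chloro holds in compound 1.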